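Swapping One Ring for Another on Compound 2

The source may hold more compounds than are shown below. What is called first, only, known or untested is meant among the compounds shown, and "the series" means these compounds.

Compound 2 `Cc1noc(C)c1-c1ccc2c(c1)C(c1ccccc1)N(Cc1nnc(-c3ccccc3)o1)C(=O)N2C` is the starting point. Among the compounds with values here, in a functional assay on MCF7 cells (Homo sapiens) for inhibition, read by MTT assay, with a stated time of 48 h, tested at 2 uM (a lower number here means less inhibition, a higher number more inhibition at the concentration tested (going by the name of the read-out)), compound 2 gives 34.1%, the higher of the two numbers recorded, but only by a margin inside the usual scatter: its one neighbour, compound 1 `Cc1noc(C)c1-c1ccc2c(c1)C(c1ccccc1)NC(=O)N2C`, gives 33.5% in this assay, and the step of a number 0.6 percentage points higher from compound 1 to compound 2 (within the scatter) changes nothing that can be trusted.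

Compound 3 `Cc1noc(C)c1-c1ccc2c(c1)C(c1ccccc1)N(Cc1ncc(-c3ccccc3)o1)C(=O)N2C` is not yet measured. It differs from compound 2 in one place: 5-phenyl-1,3-oxazol-2-yl in place of 5-phenyl-1,3,4-oxadiazol-2-yl on a saturated chain carbon bound to an amide-type nitrogen in a ring.

Within the data shown here, the only measured step attached the whole (5-phenyl-1,3,4-oxadiazol-2-yl)methyl group to the amide-type nitrogen in the ring and left the read-out essentially unchanged. Among the measured compounds shown here, no measured step shows what exchanging the oxadiazole ring for the oxazole ring does. The expectation is therefore a step of no size beyond the scatter, a number 0.1 percentage points lower from compound 2 to compound 3 (within the scatter). Compound 3 is estimated at 34% in this assay, within a range from 22% to 48%.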

Compound 3, a percentage reported as inhibition, at one concentration (the size of the read-out at that concentration, not a potency): 34%
For compound 3 middle estimate and measured number coincide at the digits printed, and the stated range covers the measured number.
By their numbers in this assay, from the lowest: compounds 1, 3 and 2 (each within the scatter of the next).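

In this assay, replacing 5-phenyl-1,3,4-oxadiazol-2-yl with 5-phenyl-1,3-oxazol-2-yl gives a number 0.1 percentage points lower from compound 2 to compound 3 (within the scatter), so lowering the hetero atoms in the five-membered aromatic ring from 3 to 2 and the hydrogen-bond acceptors from 3 to 2 produces no readable change here. Measured against the parent with hydrogen on the amide-type nitrogen in the ring, the new group gives a number 0.5 percentage points higher from compound 1 to compound 3 (within the scatter), so neither group attached at this position has yet moved the read-out beyond the scatter. No evidence is available that bears on this result.

Still open, on these data alone, is whether an amine or a carboxylic acid on the phenyl ring, or a longer chain in place of the methyl link, would shift the read-out beyond the scatter. A reading at a single concentration is not a potency, so any potency differences among these compounds also remain unknown.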